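The source may report more compounds than this note shows. Statements on the series, on what has been measured and on what is new or still open speak of the compounds shown alone.

Compound 1 `Nc1ncc(-c2ccc(C(=O)N3CCC(N)CC3)cc2)nc1-c1ccc(C(F)(F)F)cc1` stands highest of the three compounds measured in a physicochemical assay for solubility, read by HPLC, using the shake flask method, in phosphate buffer, with a stated time of 2 h, at pH 6.5 (a lower number here means a less soluble compound, a higher number a more soluble compound), where compound 1 gives 88000 nM. Compound 3 `Nc1ncc(-c2ccc(C(=O)N3CC[C@H](O)C3)cc2)nc1-c1ccc(C(F)(F)F)cc1` gives 68000 nM in this assay, and compound 2 `Nc1ccc(-c2nc(-c3ccc(S(=O)(=O)C4CC4)cc3)cnc2N)cn1` gives 13000 nM. Going by the values given here, the only step that bears on the change at hand is a 1.3-fold lower number from compound 1 to compound 3 (0.11 log units; within the scatter), which stayed within the scatter even though it moved from a six-membered to a five-membered ring on the carbonyl carbon. Compound 4 `Nc1ncc(-c2ccc(C(=O)N3CCC(N)C3)cc2)nc1-c1ccc(C(F)(F)F)cc1` differs from compound 1 by 3-aminopyrrolidin-1-yl in place of 4-aminopiperidin-1-yl on a carbonyl carbon; the ring becomes five-membered while the donor and acceptor count stays the same. No step beyond the scatter is therefore expected in this assay. Compound 4 is estimated to give 80000 nM, between 40000 nM and 160000 nM, which means an expected step of a 1.1-fold lower number from compound 1 to compound 4 (0.04 log units; within the scatter).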

Compound 4, solubility: 102000 nM
Compound 4: middle estimate off by 1.3-fold (0.11 log units), on the low side; the range from low to high includes it.
By their numbers in this assay, from the lowest: compound 2; then compounds 3, 1 and 4 (each within the scatter of the next).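

In this assay, 3-aminopyrrolidin-1-yl in place of 4-aminopiperidin-1-yl on the carbonyl carbon gives a 1.2-fold higher number from compound 1 to compound 4 (0.06 log units; within the scatter) and so the amine-bearing ring can be five- or six-membered without a step beyond the scatter. Exchanging 3-hydroxypyrrolidin-1-yl for 3-aminopyrrolidin-1-yl gives a 1.5-fold higher number from compound 3 to compound 4 (0.18 log units; within the scatter) and so these three groups cannot be told apart in this measurement. No evidence is available to explain this result. The compounds shown leave open whether a carboxylic acid on the five-membered ring, or an open-chain amine in its place, would also stay within the scatter.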